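Swapping the five-membered ring on the thioether sulfur

The source may report more compounds than this note shows. Statements on the series, on what has been measured and on what is new or still open speak of the compounds shown alone.

Among the measured compounds shown here, in a functional assay on MCF7 cells (Homo sapiens) for cytotoxicity, read by MTT assay, with a stated time of 72 h (a lower number here means a stronger inhibitor, a higher number a weaker inhibitor), compound 2 `Cc1nnc(SCc2coc3ccc(Cl)cc3c2=O)o1` gives 5000 nM, the only true number among the three measured compounds. Compound 1 `Cc1nnc(SCc2cc(=O)c3ccccc3o2)s1` reaches only the limit of the assay, > 25000 nM. Compound 3 `O=c1cc(CSc2nc3ccccc3o2)c2ccc(O)c(O)c2o1` also sits at a limit, > 25000 nM. For the measured compounds named here, both limits, (the limit of > 25000 nM in this assay, at which 2 of the 3 values shown sit), leave compound 2 as the one compound with a measured strength.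

Compound 4 `Cc1nnc(SCc2coc3ccc(Cl)cc3c2=O)s1` differs from compound 2 in one place: 5-methyl-1,3,4-thiadiazol-2-yl in place of 5-methyl-1,3,4-oxadiazol-2-yl on a sulfur. Going by the values given here, no pair of measured compounds shows this change, so its size is unknown; the expected step of a 1.2-fold higher number from compound 2 to compound 4 (0.08 log units; within the scatter) in this assay is small, not beyond the usual scatter. Compound 4 is therefore estimated at 6000 nM, with a range from 2000 nM to 20000 nM.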

Compound 4, half-maximal inhibitory concentration: 13400 nM
Beside the measured number, compound 4's estimate is 2.2-fold (0.35 log units) below it; low and high end bracket the measured number.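

Among the compounds shown here, replacing 5-methyl-1,3,4-oxadiazol-2-yl with 5-methyl-1,3,4-thiadiazol-2-yl on a sulfur gives a 2.7-fold higher number from compound 2 to compound 4 (0.43 log units; beyond the scatter) in this assay and provides the first step between two true numbers. It shows that cytotoxicity in these cells responds to this single ring change, with compound 2 the stronger of the pair. Nothing shown explains the size of this step.

As far as these compounds go, what an amine or a carboxylic acid in place of the methyl group on the five-membered ring would do remains open. So does whether the same ring change would give a similar step on another core.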